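This account rests on a few compounds, and the source may have more. Where it says the series, first, only, none or still open, it means among the compounds named here.

Compound 2 `O=c1[nH]/c(=N\OCCCc2cccc(I)c2)ccn1[C@@H]1O[C@H](COP(=O)(O)OP(=O)(O)OP(=O)(O)O)[C@@H](O)[C@H]1O` carries a 3-iodophenyl group at the end of the three-carbon chain attached through the oxygen of the shared core. In a functional assay on 1321-N1 cells for agonist activity at P2Y purinoceptor 4 (Homo sapiens), read by scintillation counting and inositol phosphate accumulation (a higher number here means that more compound is needed for the effect, a lower number that less compound is needed), compound 2 gives 114 nM. For the measured compounds named here, its only comparator is compound 1 `O=c1[nH]/c(=N\OCCCc2ccc(Br)cc2)ccn1[C@@H]1O[C@H](COP(=O)(O)OP(=O)(O)OP(=O)(O)O)[C@@H](O)[C@H]1O`, which in this assay gives 141 nM, and the two values lie within the scatter of each other. Going by the values given here, the single measured step, a 1.2-fold lower number from compound 1 to compound 2 (0.09 log units; within the scatter), exchanges 4-bromophenyl for 3-iodophenyl without moving the number beyond the scatter.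

Compound 3 `O=c1[nH]/c(=N\OCCCc2cccc([N+](=O)[O-])c2)ccn1[C@@H]1O[C@H](COP(=O)(O)OP(=O)(O)OP(=O)(O)O)[C@@H](O)[C@H]1O` is the next variation on compound 2: nitro in place of iodo on an aromatic carbon, which read one bond further out is 3-iodophenyl to 3-nitrophenyl. Among the compounds with values here, no measured step exchanges a halogen for a nitro group, so the only guide is that the aromatic substituent change between compound 1 and compound 2 left the number within scatter. A step in this assay of at most modest size is therefore expected for compound 3, with no direction established beyond the scatter. The estimate for compound 3 is 150 nM, with a range from 50 nM to 500 nM. The expected step is a 1.3-fold higher number from compound 2 to compound 3 (0.12 log units; within the scatter).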

Compound 3, half-maximal effective concentration: 95 nM
Estimate against measurement, compound 3: 1.6-fold (0.20 log units) above; low and high end bracket the measured number.
By their numbers in this assay, from the lowest: compounds 3, 2 and 1 (each within the scatter of the next).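

In this assay, for the compounds shown here, the step with nitro in place of iodo on an aromatic carbon, a 1.2-fold lower number from compound 2 to compound 3 (0.08 log units; within the scatter), is the first exchange of a halogen for a different kind of substituent at this aromatic carbon: one heavy atom and no hydrogen-bond acceptors leave, three heavy atoms and two hydrogen-bond acceptors enter, and the number does not move beyond the scatter. The step that changes both the substituent and its printed ring position, 4-bromophenyl to 3-nitrophenyl, reads a 1.5-fold lower number from compound 1 to compound 3 (0.17 log units; within the scatter), so across these three compounds neither bromo, iodo nor nitro separates from the others in this assay. There is no measured information that accounts for this result.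

On these data alone, whether an amine or a carboxylic acid on the phenyl ring would move the number beyond the scatter remains open, as does the effect of a longer chain between the oxygen and the ring. The unsubstituted phenyl group and the pair 3-bromophenyl and 4-nitrophenyl would also be needed to read the substituent and its ring position separately.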